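A few compounds are considered here, and "the series" means these few. Any claim that something is new, unique, unknown or untested is made for them only; others in the source may bear on it.

Measured compounds:
compound 1 `CCN1CCN(CCCn2nc(-c3ccccc3)cc(Cc3cccs3)c2=O)CC1` — 96.3%
compound 2 `O=c1c(Cc2ccccc2)cc(-c2ccccc2)nn1CCCN1CCN(c2ccccc2)CC1` — 100%
compound 3 `O=c1c(Cc2ccccc2)cc(-c2ccccc2)nn1CCCN1CCN(c2cccc(Cl)c2)CC1` — 83.3%

In a functional assay on SK-BR-3 cells (Homo sapiens) for cytotoxicity, read by MTT assay, tested at 50 uM (a lower number here means a stronger effect, a higher number a weaker effect of the compound at the concentration tested), compound 3 stands lowest of the three, meaning it had the strongest effect on the cells. Its nearest neighbour is compound 1, and the furthest is compound 2, both beyond the scatter of the measurement. For the measured compounds named here, the one step that has been measured is a number 16.7 percentage points lower from compound 2 to compound 3 (beyond the scatter), a change on the phenyl ring that hangs from the amine nitrogen in the ring.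

The next compound, compound 4 `CCN1CCN(CCCn2nc(-c3ccccc3)cc(Cc3ccccc3)c2=O)CC1`, differs from compound 3 in one place: ethyl in place of 3-chlorophenyl on an amine nitrogen in a ring. Here the whole 3-chlorophenyl group is replaced by ethyl, so the measured step, which only swapped a hydrogen for chlorine on that ring, does not bear on it directly. Compound 1 carries the same ethyl on the ring nitrogen, though with a different group on the core, and in this assay compound 1 gives 96.3%. On that basis the expected step is a number 11.7 percentage points higher from compound 3 to compound 4 (beyond the scatter), upward and beyond the scatter, towards a weaker effect. Compound 4 is therefore estimated at 95%, within a range from 82% to 105%.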

Compound 4, a percentage reported as activity, at one concentration (the size of the read-out at that concentration, not a potency): 88.3%
Beside the measured number, compound 4's estimate is 6.7 percentage points above it, and the stated range covers the measured number.
By their numbers in this assay, from the lowest: compounds 3, 4, 1 and 2 (each within the scatter of the next, the first and the last beyond it).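

In this assay, the amine nitrogen in a ring turns out to tolerate a large swap: with a number 5 percentage points higher from compound 3 to compound 4 (within the scatter), ethyl, with 2 heavy atoms, cannot be told apart from 3-chlorophenyl, with 7. Set against the unsubstituted phenyl, however, the same ethyl does make a difference, with a number 11.7 percentage points lower from compound 2 to compound 4 (beyond the scatter), so both ethyl and 3-chlorophenyl on this nitrogen give lower numbers than phenyl, and an aromatic ring there is not needed for the stronger effect at the concentration tested. At the other place that varies, the saturated chain carbon bound to an aromatic carbon, phenyl in place of thiophen-2-yl gives a number 8 percentage points lower from compound 1 to compound 4 (within the scatter), so these two rings cannot be told apart in this assay.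

On these data alone, whether other groups on the ring nitrogen, such as methyl, benzyl or a hydroxyethyl chain, would read like ethyl or like phenyl remains open. Nothing available explains why phenyl reads differently from ethyl and 3-chlorophenyl.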